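Turning the Stereocentre of Compound 3 Around

This account rests on a few compounds, and the source may have more. Where it says the series, first, only, none or still open, it means among the compounds named here.

Three measured compounds share one core. Compound 1 `C[C@H](NC(=O)Nc1cccc(C(F)(F)F)c1)c1ccccc1` gives 94% in an ADME assay on the whole organism with Oryza sativa as the target, tested at 0.1 uM; on this read-out higher numbers stand for a weaker effect at the one concentration tested and lower numbers for a stronger effect. Going by the values given here, compound 2 `COc1cccc(NC(=O)N[C@@H](C)c2ccccc2)c1` gives 101% in this assay, and the single step measured so far, a number 7 percentage points higher from compound 1 to compound 2 (within the scatter), changes nothing beyond the scatter. Compound 3 `C[C@@H](NC(=O)Nc1cccc(Br)c1)c1ccccc1` gives 100% in this assay; it stands second highest of the three numbers, but its gaps to compound 2 and to compound 1 both lie within the scatter, so no order among the three can be read.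

Compound 4 `C[C@H](NC(=O)Nc1cccc(Br)c1)c1ccccc1` is the unmeasured partner of compound 3. How it differs: the two compounds have the same atoms and bonds and differ only in configuration as drawn: 1 of 1 stereo elements differ; a stereocentre at a saturated chain carbon is drawn R in compound 3 and S in compound 4.

Among the compounds with values here, no measured step concerns a change of configuration, so nothing directly bears on this move; the one step available, a number 7 percentage points higher from compound 1 to compound 2 (within the scatter), concerns a different change and stayed within the scatter, and all three values sit close together. A step of a number 2 percentage points lower from compound 3 to compound 4 (within the scatter) is therefore expected, nothing beyond the scatter. Compound 4 is estimated at 98% in this assay, within a range of 85% to 108%.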

Compound 4, a percentage reported as activity, at one concentration (the size of the read-out at that concentration, not a potency): 100%
Compound 4: middle estimate off by 2 percentage points, on the low side; measured number inside the range.
By their numbers in this assay, from the lowest: compounds 1, 3, 4 and 2 (each within the scatter of the next).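

In this assay, going by these compounds alone, turning the stereocentre around gives no change at the digits printed from compound 3 to compound 4 (within the scatter) in the first measured look at configuration. Bromo can now also be compared directly with the other two aromatic substituents, and a number 1 percentage points lower from compound 2 to compound 4 (within the scatter) and a number 6 percentage points higher from compound 1 to compound 4 (within the scatter) leave all three unseparated. The step between compound 3 and compound 4 can be assigned to the stereocentre alone, because nothing else changes: the fact that compounds 3 and 4 differ only in the configuration as drawn.

All four compounds lie within the scatter of one another at the single concentration tested, so neither configuration nor the choice among these three substituents has been shown to matter here. As far as these compounds go, whether an amine or a carboxylic acid on the aromatic carbon, or a longer chain at the stereocentre, would shift the number beyond the scatter stays open.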